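Removing One Chloro Group from a Purine-Like Core

A few compounds are considered here, and "the series" means these few. Any claim that something is new, unique, unknown or untested is made for them only; others in the source may bear on it.

Measured so far:
- Compound 1 `ClCc1ccccc1Cn1cnc2c(Cl)nc(Cl)nc21`: 6910 nM
- Compound 2 `ClCc1ccccc1Cn1cnc2c(Cl)ncnc21`: 85100 nM
- Compound 3 `ClCc1ccc(Cn2cnc3nc(Cl)nc(Cl)c32)cc1`: 18200 nM

In a functional assay on SK-OV-3 cells (Homo sapiens) for cytotoxicity, read by sulforhodamine B assay, with a stated time of 48 h (on this read-out higher numbers stand for lower toxicity in this test and lower numbers for higher toxicity in this test), compound 1 gives 6910 nM. The change hydrogen in place of chloro on an aromatic carbon produced a 12-fold higher number from compound 1 to compound 2 (1.09 log units; beyond the scatter). Compound 3 carries the same atoms as compound 1 joined differently; the difference between the two cores is not broken down here. Compound 4 `ClCc1ccc(Cn2cnc3ncnc(Cl)c32)cc1` has not yet been measured. Among the measured compounds shown here, it differs from compound 3 by hydrogen in place of chloro on an aromatic carbon, which is the same change as the one from compound 1 to compound 2.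

For the measured compounds named here, the expected step is a 9.9-fold higher number from compound 3 to compound 4 (1.00 log units; beyond the scatter), because the one earlier example of this change gave a 12-fold higher number from compound 1 to compound 2 (1.09 log units; beyond the scatter). Compound 4 is therefore expected to give about 180000 nM in this assay. The estimated range for compound 4 runs from 50000 nM to 600000 nM.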

Compound 4, concentration lethal to 50% of the cells: 47900 nM
Estimate against measurement, compound 4: 3.8-fold (0.57 log units) above; measured number below the stated range.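

In this assay, hydrogen in place of chloro again gives a 2.6-fold higher number from compound 3 to compound 4 (0.42 log units; beyond the scatter) and so moves the number the same way on the second core. The size of the step does not carry over from one core to the other, however: the same change on two cores in this assay, a 12-fold higher number (1.09 log units; beyond the scatter) from compound 1 to compound 2 and a 2.6-fold higher number (0.42 log units; beyond the scatter) from compound 3 to compound 4, 4.7-fold (0.67 log units) apart, beyond the scatter of two such steps

Two pairs alone do not show why the steps differ, or what size of step a third core would give.

The compounds shown carry only chloro or hydrogen on the aromatic carbon between two ring nitrogen atoms, so the effect of an amine or a methoxy group at that place remains open. All four compounds also keep the chloromethyl group, which leaves open what a hydroxymethyl group there would give.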